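Swapping a halogenated bicycle across two related cores

The source may report more compounds than this note shows. Statements on the series, on what has been measured and on what is new or still open speak of the compounds shown alone.

Compound 1 `O=C1O/C(=C\Cn2cnc3cncc(Br)c32)C(OCc2ccccc2)=C1OCc1ccccc1`: 32900 nM
Compound 2 `O=C1NC(O)(CCn2cnc3cncc(Br)c32)C(OCc2ccccc2)=C1OCc1ccccc1`: > 100000 nM
Compound 3 `O=C1NC(O)(CCn2cnc3ccnc(Cl)c32)C(OCc2ccccc2)=C1OCc1ccccc1`: > 100000 nM

For the measured compounds named here, in a functional assay on SW-620 cells (Homo sapiens) for antiproliferative activity, read by MTT assay, with a stated time of 72 h (on this read-out higher numbers stand for weaker inhibition and lower numbers for stronger inhibition), compound 1 gives 32900 nM, the only number among the three measured compounds. For compound 2 the read-out is a limit of the assay, > 100000 nM. For compound 3 the read-out is likewise a limit, > 100000 nM. The difference between the cores of compound 1 and compound 2 is not broken down here. The step that the two limits leave unreadable from compound 2 to compound 3 corresponds to the change (a group of 10 heavy atoms (6 carbon, 3 nitrogen, 1 chlorine; one five-membered aromatic ring with 2 hetero atoms, one six-membered aromatic ring with 1 hetero atom) in place of a group of 10 heavy atoms (6 carbon, 3 nitrogen, 1 bromine; one five-membered aromatic ring with 2 hetero atoms, one six-membered aromatic ring with 1 hetero atom), on a saturated chain carbon, two bonds along the chain from a saturated ring carbon); its size cannot be read, since both compounds sit at the limit of > 100000 nM in this assay, at which 2 of the 3 values shown sit. Compound 4 `O=C1O/C(=C\Cn2cnc3ccnc(Cl)c32)C(OCc2ccccc2)=C1OCc1ccccc1` carries the same kind of change on the core of compound 1, (a group of 10 heavy atoms (6 carbon, 3 nitrogen, 1 chlorine; one five-membered aromatic ring with 2 hetero atoms, one six-membered aromatic ring with 1 hetero atom) in place of a group of 10 heavy atoms (6 carbon, 3 nitrogen, 1 bromine; one five-membered aromatic ring with 2 hetero atoms, one six-membered aromatic ring with 1 hetero atom), on a saturated chain carbon bound to a double-bonded chain carbon), though here the place is a saturated chain carbon bound to a double-bonded chain carbon rather than one two bonds along the chain from a saturated ring carbon. With no readable precedent, compound 4 is expected to stay close to compound 1, an estimated step of a 1.1-fold higher number from compound 1 to compound 4 (0.03 log units; within the scatter). Compound 4 is thus estimated at 35000 nM, plausibly anywhere from 10000 nM to 120000 nM.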

Compound 4, half-maximal inhibitory concentration: > 100000 nM
Compound 4 gave a limit, no number; the forecaster's own chance of this, stated with the estimate: 30%; at least 2.8-fold (0.45 log units) between middle value and limit.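

In this assay compound 4 gives > 100000 nM, which is a limit of the assay and not a number. On these data alone, on the core of compound 1, the chlorine-bearing group in place of the bromine-bearing group therefore means an at least 3.0-fold higher number from compound 1 to compound 4 (0.48 log units; beyond the scatter), a step whose full size stays unknown. On the other core the same kind of change cannot be read, so the data do not show whether the change carries over from one core to the other: the limit of > 100000 nM in this assay, at which 3 of the 4 values shown sit.

As far as these compounds go, it remains open whether an amine or a methyl group in place of the halogen would give a readable number on the core of compound 1. From the compounds shown here alone, it also remains open whether any such group would bring the core of compound 2 off the limit.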